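Adding a hydroxyethylamino group to compound 3

The compounds below may be only part of what the source reports. "The series", "measured", "known", "first", "only" and "open" are said of these compounds alone.

Values in a functional assay on SNU-638 cells (Homo sapiens) for inhibition, read by sulforhodamine B assay, with a stated time of 2 days (a higher number here means a weaker inhibitor of growth, a lower number a stronger inhibitor of growth), so far:
- compound 1 `N#Cc1cc2c(N)ncnc2nc1Nc1ccc(S(N)(=O)=O)cc1` gives 19300 nM
- compound 2 `N#Cc1cc2c(N)nc(NCCO)nc2nc1NCCO` gives 10900 nM
- compound 3 `Cc1c(C#N)c(Nc2ccc(S(N)(=O)=O)cc2)nc2ncnc(N)c12` gives 16600 nM

Compound 3 lies within the scatter of both compound 1 and compound 2, so it cannot be ranked against either. Compound 4 `Cc1c(C#N)c(Nc2ccc(S(N)(=O)=O)cc2)nc2nc(NCCO)nc(N)c12` keeps everything in compound 3 but takes (2-hydroxyethyl)amino in place of hydrogen on an aromatic carbon, between two ring nitrogen atoms ((2-hydroxyethyl)amino in place of hydrogen on an aromatic carbon).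

Within the data shown here, the only measured step (a 1.2-fold lower number from compound 1 to compound 3 (0.07 log units; within the scatter)) is methyl in place of hydrogen on an aromatic carbon. It is a different change and stays within the scatter, so it shows only that one small substitution left this assay unmoved. Among the measured compounds shown here, compound 2 (10900 nM) is the only measured compound carrying (2-hydroxyethyl)amino, but it also differs from compound 3 elsewhere, so no clean step can be taken from it. Its value does suggest that the group need not push the number up.

A step within the scatter is therefore expected, leaning slightly towards a lower number (a 1.4-fold lower number from compound 3 to compound 4 (0.14 log units; within the scatter)). The estimated value for compound 4 is 12000 nM (4000 nM to 35000 nM).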

Compound 4, concentration for 50% growth inhibition: 38200 nM
For compound 4 the middle estimate is 3.2-fold (0.50 log units) below the measured one; measured number above the stated range.
By their numbers in this assay, from the lowest: compounds 2, 3, 1 and 4 (each within the scatter of the next, the first and the last beyond it).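

In this assay, the aromatic carbon between two ring nitrogen atoms proves to be a place where a substitution can move the number beyond the scatter: (2-hydroxyethyl)amino in place of hydrogen gives a 2.3-fold higher number from compound 3 to compound 4 (0.36 log units; beyond the scatter). Among these compounds, the only earlier single-place step, methyl in place of hydrogen on a different aromatic carbon, gave a 1.2-fold lower number from compound 1 to compound 3 (0.07 log units; within the scatter), so it gave no sign that a change to this series could shift growth inhibition; the new step, though modest, runs towards weaker inhibition, and on the core of compound 3 the group brings no gain. No supporting measurement is available to account for this shift.

The compounds shown do not tell whether the shift follows from the terminal hydroxyl, the amine link or the length of the chain, and a methylamino group or a longer hydroxyalkylamino chain at this carbon would help to separate these. On these data alone, it also remains open whether (2-hydroxyethyl)amino would give a similar step on the core of compound 1, which lacks the methyl group.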